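Carboxy-chain variation on the amide nitrogen of the shared core

A few compounds are considered here, and "the series" means these few. Any claim that something is new, unique, unknown or untested is made for them only; others in the source may bear on it.

Measured compounds:
compound 1 `O=C(O)CCC(=O)N(C1CC1)[C@H]1c2ccccc2N(C(=O)c2cccc(OC(F)(F)F)c2)[C@H]2CC[C@H]21` 43 nM
compound 2 `O=C(O)COC(=O)N(C1CC1)[C@H]1c2ccccc2N(C(=O)c2cccc(F)c2)[C@H]2CC[C@H]21` 1.1 nM
compound 3 `O=C(O)COC(=O)N(C1CC1)[C@H]1c2ccccc2N(C(=O)c2ccc(F)cc2)[C@H]2CC[C@H]21` 1.4 nM

In a functional assay on cells for antagonist activity at prostaglandin D2 receptor 2 (Homo sapiens), read by chemiluminescence and beta-arrestin recruitment, with stated times of 30 min and 60 min (on this read-out higher numbers stand for weaker inhibition and lower numbers for stronger inhibition), compound 2 gives the lowest number of the three; compound 3 sits within the scatter of it, and the step of a 1.3-fold higher number from compound 2 to compound 3 (0.10 log units; within the scatter) is small. Compound 1 gives 43 nM, a much higher number than compound 2, but compound 1 and compound 2 differ in two places, so that gap cannot be assigned to either change alone. Compound 4 `O=C(O)CCC(=O)N(C1CC1)[C@H]1c2ccccc2N(C(=O)c2cccc(F)c2)[C@H]2CC[C@H]21` carries the change (2-carboxyethyl in place of carboxymethoxy on a carbonyl carbon). For the measured compounds named here, no measured step isolates this change. Compound 4 is expected to lose potency against compound 2, the step of a 9.1-fold higher number from compound 2 to compound 4 (0.96 log units; beyond the scatter) being estimated from what compound 1 shows with 43 nM. The estimate for compound 4 is 10 nM, range 2 nM to 50 nM.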

Compound 4, half-maximal inhibitory concentration: 9.3 nM
Compound 4: the middle estimate sits 1.1-fold (0.03 log units) above what was measured, within the range that was stated.
By their numbers in this assay, from the lowest: compounds 2 and 3 (each within the scatter of the next); then compound 4; then compound 1.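

In this assay the change to 2-carboxyethyl from carboxymethoxy on a carbonyl carbon now stands alone, giving an 8.5-fold higher number from compound 2 to compound 4 (0.93 log units; beyond the scatter) as its own step. Fluoro in place of trifluoromethoxy on an aromatic carbon also stands alone, giving a 4.6-fold lower number from compound 1 to compound 4 (0.66 log units; beyond the scatter) as its step, so the earlier gap between the two chains holds contributions from both changes. No evidence bears on what lies behind either step.

Open, from the compounds shown here alone, is how a longer carboxy chain, or a tetrazole in place of the carboxylic acid, would read on the shared core.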